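This account rests on a few compounds, and the source may have more. Where it says the series, first, only, none or still open, it means among the compounds named here.

Compound 3 `COc1ccnc(-c2cnc(C(=O)CCCCCCc3ccccc3)o2)c1` stands lowest of the three numbers in an assay (Rattus norvegicus) for inhibition of Fatty-acid amide hydrolase 1 (Homo sapiens) (on this read-out lower numbers stand for stronger inhibition and higher numbers for weaker inhibition), at 0.8 nM. Compound 1 `Nc1ccc(-c2cnc(C(=O)CCCCCCc3ccccc3)o2)cc1` gives 90 nM and compound 2 `NC(=O)c1ccc(-c2cnc(C(=O)CCCCCCc3ccccc3)o2)cc1` gives 10 nM. Compound 4 `O=C(CCCCCCc1ccccc1)c1ncc(C(=O)N2CCSCC2)o1` differs from compound 3 by (thiomorpholin-4-yl)carbonyl in place of 4-methoxypyridin-2-yl on an aromatic carbon. Among the measured compounds shown here, no measured step replaces the aromatic group at this carbon with (thiomorpholin-4-yl)carbonyl; the steps that touch the same place are a 110-fold lower number from compound 1 to compound 3 (2.05 log units; beyond the scatter) and a 13-fold lower number from compound 2 to compound 3 (1.10 log units; beyond the scatter), both large, and a 9.0-fold lower number from compound 1 to compound 2 (0.95 log units; beyond the scatter), modest, so the group here swings the number widely. Because compound 3 already holds the lowest number, 0.8 nM, the change is expected to give a higher number, about a 19-fold higher number from compound 3 to compound 4 (1.27 log units; beyond the scatter), with wide uncertainty. Compound 4 is estimated at 15 nM, range 2 nM to 150 nM.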

Compound 4, inhibition constant: 10 nM
For compound 4 the middle estimate is 1.5-fold (0.18 log units) above the measured one; measured number inside the range.
By their numbers in this assay, from the lowest: compound 3; then compounds 2 and 4 (each within the scatter of the next); then compound 1.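

A non-aromatic group is compatible with this carbon: with (thiomorpholin-4-yl)carbonyl in place of 4-carbamoylphenyl, this assay shows no change at the digits printed from compound 2 to compound 4 (within the scatter). An aromatic ring here is therefore not required for a low number, yet the outcome depends on the group replaced, with a 9.0-fold lower number from compound 1 to compound 4 (0.95 log units; beyond the scatter) but a 13-fold higher number from compound 3 to compound 4 (1.10 log units; beyond the scatter). No evidence is available to explain these differences.

The compounds shown leave open whether the carbonyl, the ring sulfur or the whole ring carries the result. A morpholine amide, a piperidine amide or a dimethylamide at this carbon would separate these parts.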